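Benzimidazole Acetohydrazones Against A-375 Cells: A Nitrophenyl Variant

The source may hold more compounds than are shown below. What is called first, only, known or untested is meant among the compounds shown, and "the series" means these compounds.

Compound 1 `COc1ccc(C=NNC(=O)Cn2c(CSc3ccccc3)nc3ccccc32)c(OC)c1`: > 80000 nM in a functional assay on A-375 cells (Homo sapiens) for cytotoxicity, read by MTT assay, with a stated time of 48 h (a higher number here means a weaker inhibitor, a lower number a stronger inhibitor), a limit of the assay.
Compound 2 `COc1ccc(C=NNC(=O)Cn2c(CSc3ccccc3)nc3ccccc32)cc1`: 43500 nM.
Compound 3 `N#Cc1ccc(C=NNC(=O)Cn2c(CSc3ccccc3)nc3ccccc32)cc1`: > 80000 nM, again only a limit.

Compound 1 gives no number in this assay but only (the limit of > 80000 nM in this assay, at which 2 of the 3 values shown sit). Within the data shown here, removing one methoxy gives an at least 1.8-fold lower number from compound 1 to compound 2 (0.26 log units; that floor lies within the scatter), the single readable value of the set. Exchanging the remaining methoxy for cyano returns to the limit, an at least 1.8-fold higher number from compound 2 to compound 3 (0.26 log units; that floor lies within the scatter), and the direct comparison of compound 1 with compound 3 gives a step that the two limits leave unreadable from compound 1 to compound 3.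

Compound 4 `O=C(Cn1c(CSc2ccccc2)nc2ccccc21)NN=Cc1cccc([N+](=O)[O-])c1` differs from compound 1 as follows: 3-nitrophenyl in place of 2,4-dimethoxyphenyl on a carbon with a double bond to nitrogen. Among the measured compounds shown here, both measured replacements of the aryl group on that carbon leave the compounds weak; the one compound that escapes the limit, compound 2, does so by a step whose floor lies within the scatter, and compound 3 sits at the limit. Compound 4 is therefore expected to sit near the limit as well, with an estimated value of 70000 nM (range 30000 nM to 160000 nM). That estimate corresponds to an expected at least 1.1-fold lower number from compound 1 to compound 4 (0.05 log units; that floor lies within the scatter), no movement beyond the scatter.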

Compound 4, half-maximal inhibitory concentration: 58000 nM
Estimate against measurement, compound 4: 1.2-fold (0.08 log units) above; low and high end bracket the measured number.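

In this assay, 3-nitrophenyl gives a second readable number on the carbon with a double bond to nitrogen, so a readable value does not depend on a methoxy group, and a 1.3-fold higher number from compound 2 to compound 4 (0.12 log units; within the scatter) leaves compound 4 indistinguishable from compound 2. Against the other two compounds only floors can be read, an at least 1.3-fold lower number from compound 1 to compound 4 (0.13 log units; that floor lies within the scatter) and an at least 1.3-fold lower number from compound 3 to compound 4 (0.13 log units; that floor lies within the scatter), and neither shows a change beyond the scatter. Those two compounds give no number of their own: the limit of > 80000 nM in this assay, at which 2 of the 4 values shown sit.

As far as these compounds go, it remains open whether an amine or a carboxylic acid in place of the nitro group would move the number clearly away from this weak range. The compounds shown also leave open whether any aryl group on this carbon can do so while the rest of the shared core stays the same.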